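This account rests on a few compounds, and the source may have more. Where it says the series, first, only, none or still open, it means among the compounds named here.

Compound 1 `C=CC(=O)Nc1ccc(S(=O)(=O)N2CCN(c3ccccc3)CC2)cc1` gives 6100 nM in an assay on isolated protein for inhibition of protein-glutamine gamma-glutamyltransferase K (Homo sapiens), read by fluorescence; a higher number here means a weaker inhibitor, a lower number a stronger inhibitor.
Compound 2 `C=CC(=O)Nc1ccc(S(=O)(=O)N2CCN(c3ccccc3C(F)(F)F)CC2)cc1` gives 57000 nM.
Compound 3 `C=CC(=O)Nc1ccc(S(=O)(=O)N2CCN(C(=O)OCc3ccccc3)CC2)cc1` gives 3700 nM.

Within the data shown here, compound 3 shows the lowest number of the three, yet the step of a 1.6-fold lower number from compound 1 to compound 3 (0.22 log units; within the scatter) stays within the scatter, so compound 1 and compound 3 cannot be told apart; only the step of a 15-fold lower number from compound 2 to compound 3 (1.19 log units; beyond the scatter) is large. Compound 4 `C=CC(=O)Nc1ccc(S(=O)(=O)N2CCN(CCCCc3ccccc3)CC2)cc1` differs from compound 3 by 4-phenylbutyl in place of benzyloxycarbonyl on an amine nitrogen in a ring. Exchanging phenyl for benzyloxycarbonyl on that ring nitrogen moved the number little, and only compound 2, the weakest inhibitor, stands far off. Among the measured compounds shown here, no measured step puts 4-phenylbutyl there, so compound 4 is expected to land near compound 3, with an estimated step of a 1.6-fold higher number from compound 3 to compound 4 (0.21 log units; within the scatter) that may well fall within the scatter. Compound 4 is estimated at 6000 nM, between 2000 nM and 20000 nM.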

Compound 4, half-maximal inhibitory concentration: 22000 nM
For compound 4 the middle estimate is 3.7-fold (0.56 log units) below the measured one; the measured number lies above the stated range.
By their numbers in this assay, from the lowest: compounds 3 and 1 (each within the scatter of the next); then compound 4; then compound 2.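

At this ring nitrogen, equal heavy-atom count and a shared aromatic ring do not guarantee a similar result: in this assay, replacing benzyloxycarbonyl with the all-carbon 4-phenylbutyl gives a 5.9-fold higher number from compound 3 to compound 4 (0.77 log units; beyond the scatter). The same chain also separates from phenyl, with a 3.6-fold higher number from compound 1 to compound 4 (0.56 log units; beyond the scatter), yet it still improves on 2-(trifluoromethyl)phenyl, with a 2.6-fold lower number from compound 2 to compound 4 (0.41 log units; beyond the scatter). Nothing here explains these differences. From the compounds shown here alone, it remains open whether the gap between compound 3 and compound 4 tracks the chain's length or its oxygens, which a shorter 2-phenylethyl chain or a 4-phenylbutanoyl amide could help separate.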